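Acyl sulfonamide in place of carboxylic acid at the benzylic end

The compounds below may be only part of what the source reports. "The series", "measured", "known", "first", "only" and "open" are said of these compounds alone.

Working notes on a small series read in a functional assay on HEK293 cells for agonist activity at Bile acid receptor (Homo sapiens); a lower number here means a smaller maximal response, a higher number a larger maximal response. Among the compounds with values here, compound 1 `CC(C)c1onc(-c2c(Cl)cccc2Cl)c1COc1ccc(N(C)Cc2cccc(C(=O)O)c2)c(C(F)(F)F)n1` gives 89% in this assay and stands highest of the two numbers so far. Compound 2 `CC(C)c1onc(-c2c(Cl)cccc2Cl)c1COc1ccc(N(C)Cc2ccc(OCC(=O)O)cc2)c(C(F)(F)F)n1` gives 69% in this assay. Within the data shown here, the one measured step is a number 20 percentage points lower from compound 1 to compound 2 (beyond the scatter), a modest loss beyond the scatter, brought by 4-(carboxymethoxy)phenyl in place of 3-carboxyphenyl on a saturated chain carbon bound to a nitrogen on an aromatic ring.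

Compound 3 `CC(C)c1onc(-c2c(Cl)cccc2Cl)c1COc1ccc(N(C)Cc2cccc(C(=O)NS(C)(=O)=O)c2)c(C(F)(F)F)n1` is not yet measured. It differs from compound 1 by methanesulfonamido in place of hydroxy on a carbonyl carbon, so carboxy becomes (methylsulfonyl)carbamoyl while the 3-substituted phenyl is kept. Among the measured compounds shown here, no measured step covers this change; the step from compound 1 to compound 2 bears on it only in showing that rebuilding the carboxy-bearing end costs a modest amount of maximal response. Since the ring and its substitution pattern are retained here, a smaller step than that one is expected, downward if any. Compound 3 is estimated at 80% in this assay, with a range from 58% to 100%, which means an expected step of a number 9 percentage points lower from compound 1 to compound 3 (within the scatter).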

Compound 3, largest response reached (reported as efficacy), in percent of the reference or control that the assay uses: 59%
Estimate against measurement, compound 3: 21 percentage points above, and the stated range covers the measured number.
By their numbers in this assay, from the lowest: compounds 3 and 2 (each within the scatter of the next); then compound 1.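

In this assay, within the data shown here, the position on the carbonyl carbon proves sensitive even with the 3-substituted phenyl kept: with methanesulfonamido in place of hydroxy as the only change, the result is a number 30 percentage points lower from compound 1 to compound 3 (beyond the scatter). The earlier pair rebuilt the whole carboxy-bearing end, ring substitution included, so it could not show that an edit confined to the carboxy group is enough to lower the maximal response. Carboxy to (methylsulfonyl)carbamoyl is therefore not a neutral exchange in this series, although compound 3 still retains a clear response at 59%. No supporting data bear on the origin of the loss, so only its size can be stated.

On these data alone, it remains open whether the loss belongs to the carbamoyl link or to the methylsulfonyl part, and a primary carboxamide or a tetrazole on the same aromatic carbon would help separate the two. A phenylsulfonyl or cyclopropylsulfonyl group in place of methylsulfonyl would show whether the response changes with what is carried on the sulfur.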